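The compounds below may be only part of what the source reports. "The series", "measured", "known", "first", "only" and "open" are said of these compounds alone.

Measured so far in an ADME assay on microsomes from liver (Mus musculus) for metabolic stability, read by LC-MS, with a stated time of 30 min, tested at 1 ug/mL; on this read-out higher numbers stand for a more stable compound and lower numbers for a less stable compound:
Compound 1 `CC(C)C(=O)N1CCC(C[C@@H](c2nc3ccc(F)cc3n2C2CC2)N2C(=O)CN(c3ccc(Oc4ccc(F)cc4)cc3)C2=O)CC1` gives 54%
Compound 2 `COc1ccc(Oc2ccc(N3CC(=O)N([C@@H](CC4CCN(C(=O)C(C)C)CC4)c4nc5ccc(F)cc5n4C)C3=O)cc2)cc1` gives 24.1%

Of these two numbers, compound 2 has the lower one, and compound 1 stands above it by more than the usual scatter. The next compound to be tested is compound 3 `CC(C)C(=O)N1CCC(C[C@@H](c2nc3ccc(F)cc3n2C)N2C(=O)CN(c3ccc(Oc4ccc(F)cc4)cc3)C2=O)CC1`, which departs from compound 2 in a single place: fluoro in place of methoxy on an aromatic carbon. The 4-methoxyphenoxy of compound 2 thus becomes 4-fluorophenoxy. Within the data shown here, no measured pair shows this change alone, so the data give no direct size for it. Among the measured compounds shown here, the only pointer is compound 1 at 54% (it also carries 4-fluorophenoxy), but it differs from compound 2 elsewhere too, so it offers weak support. A rise in this assay beyond the scatter is therefore expected, though with little confidence, and the estimated move is a number 17.9 percentage points higher from compound 2 to compound 3 (beyond the scatter) (a rough figure). For compound 3 the estimated value is 42% (expected range 26% to 60%).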

Compound 3, percent of the compound remaining: 26.4%
Compound 3: the middle estimate sits 15.6 percentage points above what was measured, within the range that was stated.
By their numbers in this assay, from the lowest: compounds 2 and 3 (each within the scatter of the next); then compound 1.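

In this assay, fluoro in place of methoxy on an aromatic carbon, para to a large group, gives a number 2.3 percentage points higher from compound 2 to compound 3 (within the scatter), so on this background the exchange of 4-methoxyphenoxy for 4-fluorophenoxy leaves the read-out without a difference that can be told from the scatter. The second single change, methyl in place of cyclopropyl on an aromatic nitrogen, gives a number 27.6 percentage points lower from compound 1 to compound 3 (beyond the scatter), and of the two single changes now readable, only this one lies beyond the scatter. Nothing available explains either outcome.

The compounds shown leave open whether the exchange of methoxy and fluoro would also stay within the scatter with cyclopropyl on the aromatic nitrogen, as each of the two changes is seen in one pair only and on one background. They also leave open where other groups would fall in this assay, such as ethyl, isopropyl or cyclobutyl on that nitrogen, or chloro or a nitrile in place of fluoro on the phenoxy ring.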